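Piperazine chain on the pyrrolidine compound's core

A few compounds are considered here, and "the series" means these few. Any claim that something is new, unique, unknown or untested is made for them only; others in the source may bear on it.

Measured in a functional assay on A549 cells (Homo sapiens) for cytotoxicity, read by MTT assay, with a stated time of 72 h; on this read-out lower numbers stand for stronger inhibition and higher numbers for weaker inhibition:
- compound 1 `CN(C)CCCCCn1c2c(c3ccccc31)C(=O)c1c[n+]([O-])c3ccccc3c1C2=O`: 210 nM
- compound 2 `CN1CCN(CCCCn2c3c(c4ccccc42)C(=O)c2c[n+]([O-])c4ccccc4c2C3=O)CC1`: 90 nM
- compound 3 `O=C1c2c[n+]([O-])c3ccccc3c2C(=O)c2c1c1ccccc1n2CCN1CCCC1`: 410 nM

On these numbers, compound 3 sits at the weak end together with compound 1, as the step of a 2.0-fold higher number from compound 1 to compound 3 (0.29 log units; within the scatter) shows. Compound 2 stands apart, with a 4.6-fold higher number from compound 2 to compound 3 (0.66 log units; beyond the scatter).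

The next compound, compound 4 `O=C1c2c[n+]([O-])c3ccccc3c2C(=O)c2c1c1ccccc1n2CCCCN1CCNCC1`, differs from compound 3 by 2-(piperazin-1-yl)ethyl in place of pyrrolidin-1-yl on a saturated chain carbon, two bonds along the chain from an aromatic nitrogen. In words, this is 2-(piperazin-1-yl)ethyl in place of pyrrolidin-1-yl on a saturated chain carbon, two bonds along the chain from an aromatic nitrogen.

The closest guide is a 4.6-fold higher number from compound 2 to compound 3 (0.66 log units; beyond the scatter), a modest step at the same place, involving 2-(4-methylpiperazin-1-yl)ethyl. Read backwards, it points to a lower number for compound 4. Within the data shown here, the modest step of a 2.3-fold lower number from compound 1 to compound 2 (0.37 log units; beyond the scatter) also favours a piperazine-bearing chain, but no compound with an unsubstituted piperazine has been measured. In this assay, a modest drop is therefore expected, with the estimated step being a 3.2-fold lower number from compound 3 to compound 4 (0.50 log units; beyond the scatter). Compound 4 is estimated at 130 nM, within an expected range of 50 nM to 330 nM.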

Compound 4, half-maximal inhibitory concentration: 540 nM
Beside the measured number, compound 4's estimate is 4.2-fold (0.62 log units) below it; measured number outside the range, above it.
By their numbers in this assay, from the lowest: compound 2; then compounds 1, 3 and 4 (each within the scatter of the next, the first and the last beyond it).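

In this assay the change from pyrrolidin-1-yl to 2-(piperazin-1-yl)ethyl at this chain carbon gives a 1.3-fold higher number from compound 3 to compound 4 (0.12 log units; within the scatter) and so cannot be told apart from no change at all. What the earlier compounds could not show is the role of the methyl on the ring amine nitrogen: hydrogen in its place gives a 6.0-fold higher number from compound 2 to compound 4 (0.78 log units; beyond the scatter) and accounts for the clearest difference in the set, so the low number of compound 2 goes with the methylated piperazine and not with any piperazine chain. The comparison with the dimethylamino chain gives a 2.6-fold higher number from compound 1 to compound 4 (0.41 log units; beyond the scatter) and points the same way, with the unsubstituted ring on the weaker side. Nothing available here explains the effect of the methyl. Still open, on these data alone, is whether an ethyl or a 2-hydroxyethyl group on that ring nitrogen would match the methyl.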